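Nitro in Place of Amino: What the Numbers Suggest

The source may report more compounds than this note shows. Statements on the series, on what has been measured and on what is new or still open speak of the compounds shown alone.

Compound 1, `COc1ccc(-c2cc3ccccc3nc2/C=C/C(=O)c2ccc(O)cc2)cc1`: 3880 nM
Compound 2, `COc1ccc(-c2cc3ccccc3nc2/C=C/C(=O)c2ccc(N)cc2)cc1`: 8560 nM

In a functional assay on SK-BR-3 cells (Homo sapiens) for antiproliferative activity, read by XTT assay, with a stated time of 72 h (a higher number here means a weaker inhibitor, a lower number a stronger inhibitor), compound 1 gives 3880 nM, and compound 2 gives 8560 nM. Going by the values given here, compound 2 therefore stands with the higher of the two numbers, its nearest neighbour being compound 1, and the single measured step is a 2.2-fold higher number from compound 1 to compound 2 (0.34 log units; beyond the scatter). The unmeasured compound 3, `COc1ccc(-c2cc3ccccc3nc2/C=C/C(=O)c2ccc([N+](=O)[O-])cc2)cc1`, departs from compound 2 by nitro in place of amino on an aromatic carbon. Among the compounds with values here, only the step from compound 1 to compound 2 bears on this change, and only loosely, since it exchanged hydroxy for amino rather than amino for nitro; it was modest in size. Nothing measured here speaks directly to the nitro group. The expected step is a 1.2-fold lower number from compound 2 to compound 3 (0.09 log units; within the scatter), which may fall within the scatter in either direction. Compound 3 is estimated at 7000 nM, within 2500 nM to 20000 nM.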

Compound 3, half-maximal inhibitory concentration: 590 nM
For compound 3 the middle estimate is 12-fold (1.07 log units) above the measured one; the whole stated range lies above it.
By their numbers in this assay, from the lowest: compound 3; then compound 1; then compound 2.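

In this assay, the change from 4-aminophenyl to 4-nitrophenyl gives a large step (a 15-fold lower number from compound 2 to compound 3 (1.16 log units; beyond the scatter)), far greater than the modest step from hydroxy to amino at this position (a 2.2-fold higher number from compound 1 to compound 2 (0.34 log units; beyond the scatter)). Nitro also stands apart from hydroxy (a 6.6-fold lower number from compound 1 to compound 3 (0.82 log units; beyond the scatter)), so compound 3 is the strongest of the three, and the group at this position can move the number much further than the earlier pair showed. Nothing available here bears on the reason for this result.

The compounds shown leave open whether a nitrile, a carboxylic acid or a methyl ester at this position would stand with nitro or with hydroxy and amino. They also leave open whether the advantage of nitro would persist if the methoxy group elsewhere in the shared core were replaced by an amine.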